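The source may report more compounds than this note shows. Statements on the series, on what has been measured and on what is new or still open speak of the compounds shown alone.

Compound 1 `COc1cc(OC)c(-c2coc3cc(OCc4ccccc4)ccc3c2=O)cc1OC`: in a functional assay on HUVEC cells (Homo sapiens) for antiproliferative activity, read by MTT assay, with a stated time of 24 h (on this read-out higher numbers stand for weaker inhibition and lower numbers for stronger inhibition), compound 1 gives 9750 nM.
Compound 2 `COc1cc(OC)c(-c2coc3cc(OCc4ccccc4C(F)(F)F)ccc3c2=O)cc1OC`: in this assay compound 2 reaches only the assay limit > 10000 nM.
Compound 3 `COc1cc(OC)c(-c2coc3cc(OCc4cccc(Cl)c4)ccc3c2=O)cc1OC`: in this assay compound 3 reaches only the assay limit > 10000 nM.

Compound 1 stands as the only one of the three with a measured number in this assay; the other two values are limits, not numbers. The account follows the step from compound 1 to compound 4 `COc1cc(OC)c(-c2coc3cc(OCc4ccccc4Br)ccc3c2=O)cc1OC`, which differs from compound 1 by bromo in place of hydrogen on an aromatic carbon.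

For the measured compounds named here, two measured steps bear on this change, since both also put a single group onto the same six-membered ring of the benzyl part. From compound 1 to compound 2 the step reads an at least 1.0-fold higher number from compound 1 to compound 2 (0.01 log units; that floor lies within the scatter), and from compound 1 to compound 3 it reads an at least 1.0-fold higher number from compound 1 to compound 3 (0.01 log units; that floor lies within the scatter). The endpoints of both steps sit at the limit of > 10000 nM in this assay, at which 2 of the 3 values shown sit, so their true size is not readable. Between compound 2 and compound 3 the step is a step that the two limits leave unreadable from compound 2 to compound 3.

On this basis the writer expects the step from compound 1 to compound 4 to be small, if anything upward, at a 1.2-fold higher number from compound 1 to compound 4 (0.09 log units; within the scatter), with a real chance that this assay again reports only a limit. For compound 4 the estimate in this assay is 12000 nM, expected to lie between 6000 nM and 30000 nM.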

Compound 4, half-maximal inhibitory concentration: > 10000 nM
Compound 4 gave a limit, no number; the forecaster's own chance of this, stated with the estimate: 65%; the middle value lies beyond the limit too.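

In this assay compound 4 reaches only the limit > 10000 nM and gives no number. For the compounds shown here, the one step that can be read is an at least 1.0-fold higher number from compound 1 to compound 4 (0.01 log units; that floor lies within the scatter) and it is only a floor, so the true size of putting bromo on this aromatic carbon, ortho to a large group, stays unknown, while the steps from compound 3 to compound 4 and from compound 2 to compound 4 cannot be read at all. What compound 4 adds is a third benzyl group carrying a single added group, here 2-bromobenzyl, that yields a limit, which leaves compound 1 still the only compound with a number: the limit of > 10000 nM in this assay, at which 3 of the 4 values shown sit.

The compounds shown leave open how far compound 2, compound 3 and compound 4 lie from compound 1, since none of the three has a number. They also leave open whether a different group on this ring, such as an amine or a carboxylic acid, would give a measured value lower than that of compound 1.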